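The source may hold more compounds than are shown below. What is called first, only, known or untested is meant among the compounds shown, and "the series" means these compounds.

Measured compounds in the series:

Compound 1, `Cc1cc(NC(=O)Nc2ccccc2F)c2ccccc2n1`, gives > 25000 nM in an ADME assay on BJ cells (Homo sapiens) for cytotoxicity, with a stated time of 72 h; a higher number here means that more compound is needed for the effect, a lower number that less compound is needed; this is a limit of the assay, not a number.
Compound 2, `Cc1cc(NC(=O)Nc2cccc(Cl)c2)c2ccccc2n1`, gives > 25000 nM in this assay; again a limit, not a number.
Compound 3, `Cc1cc(NC(=O)Nc2ccc(O)cc2)c2ccccc2n1`, gives > 25000 nM in this assay; again a limit, not a number.

Going by the values given here, compound 2 therefore stands where every measured compound stands: all three values sit at the limit of > 25000 nM in this assay, at which 3 of the 3 values shown sit, and no compound can be ordered against another. The three steps among them, a step that the two limits leave unreadable from compound 1 to compound 2, a step that the two limits leave unreadable from compound 1 to compound 3 and a step that the two limits leave unreadable from compound 2 to compound 3, are unreadable for the same reason, so none of them shows how changes on the aryl urea ring move the read-out.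

Compound 4, `COc1cccc(NC(=O)Nc2cc(C)nc3ccccc23)c1`, is not yet measured. Its change from compound 2 is methoxy in place of chloro on an aromatic carbon. Among the compounds with values here, no measured step bears on this change in a readable way; the only guidance is that three aryl variants, including compound 2, all sit at the limit. The step from compound 2 to compound 4 is therefore expected to be a step that the limit leaves unreadable from compound 2 to compound 4, that is, none beyond the scatter, with the result most likely reported again as a limit. Compound 4 is estimated at 40000 nM in this assay, within 15000 nM to 120000 nM.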

Compound 4, half-maximal effective concentration: 27000 nM
Compound 4: middle estimate off by 1.5-fold (0.17 log units), on the high side, and the stated range covers the measured number.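

In this assay compound 2 gives > 25000 nM, a limit and not a number. Compound 4 gives 27000 nM, so no new step can be read between it and compound 2. The compounds shown leave open where compound 1, compound 2 and compound 3 lie beyond their limits, and so how changes on the aryl urea ring move the read-out.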